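The source may report more compounds than this note shows. Statements on the series, on what has been measured and on what is new or still open speak of the compounds shown alone.

In an ADME assay on MDCKII-LE cells (Canis lupus familiaris) for permeability (on this read-out higher numbers stand for higher permeability and lower numbers for lower permeability), three compounds have been measured so far. Compound 1 `N#C[C@H]1C[C@@H]1CN([C@H](CCC(F)(F)F)C(N)=O)S(=O)(=O)c1ccc(Cl)cc1` gives 21.5 10^-6 cm/s, compound 2 `N#C[C@@H]1C[C@H]1CN([C@H](CCC(F)(F)F)C(N)=O)S(=O)(=O)c1ccc(Cl)cc1` gives 9.94 10^-6 cm/s, and compound 3 `N#C[C@H]1C[C@H](CN([C@H](CCC(F)(F)F)C(N)=O)S(=O)(=O)c2ccc(Cl)cc2)C1` gives 24.9 10^-6 cm/s. The numbers show a 1.2-fold higher number from compound 1 to compound 3 (0.06 log units; within the scatter), so compound 3 cannot be told apart from compound 1. They also show a 2.5-fold higher number from compound 2 to compound 3 (0.40 log units; beyond the scatter), which places compound 3 clearly apart from compound 2. The remaining pair shows a 2.2-fold lower number from compound 1 to compound 2 (0.34 log units; beyond the scatter), due to the fact that compounds 1 and 2 differ only in the configuration as drawn.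

Compound 4 `NC(=O)[C@@H](CCC(F)(F)F)N(C[C@H]1C[C@@H](c2ncon2)C1)S(=O)(=O)c1ccc(Cl)cc1` has not yet been measured. It carries 3-(1,2,4-oxadiazol-3-yl)cyclobutyl in place of 3-cyanocyclobutyl on a saturated chain carbon bound to a sulfonamide nitrogen, and the count of what changes reads (3-(1,2,4-oxadiazol-3-yl)cyclobutyl in place of 3-cyanocyclobutyl on a saturated chain carbon bound to a sulfonamide nitrogen). Among the compounds with values here, no measured step replaces the nitrile itself, so the steps at the ring that carries it offer the only guide to size. Those steps are small, since even the largest of them is a 2.5-fold higher number from compound 2 to compound 3 (0.40 log units; beyond the scatter). A step of similar modest size is therefore the most that is expected here, with a slightly lower number as the more likely direction. The expected change is a 1.4-fold lower number from compound 3 to compound 4 (0.14 log units; within the scatter). For compound 4 the estimated value is 18 10^-6 cm/s, with an expected range from 9 10^-6 cm/s to 34 10^-6 cm/s.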

Compound 4, apparent permeability: 14.1 10^-6 cm/s
Compound 4: middle estimate off by 1.3-fold (0.11 log units), on the high side; the range from low to high includes it.
By their numbers in this assay, from the lowest: compounds 2, 4, 1 and 3 (each within the scatter of the next, the first and the last beyond it).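

In this assay, within the data shown here, the nitrile itself is exchanged for the first time, and the step reads a 1.8-fold lower number from compound 3 to compound 4 (0.25 log units; within the scatter) for that exchange. Thus the group 3-(1,2,4-oxadiazol-3-yl)cyclobutyl, with 9 heavy atoms and 3 hydrogen-bond acceptors against 6 and 1 in 3-cyanocyclobutyl, can sit on a saturated chain carbon bound to a sulfonamide nitrogen without a difference that stands clear of the scatter. Measured against the two 2-cyanocyclopropyl compounds, the steps read a 1.4-fold higher number from compound 2 to compound 4 (0.15 log units; within the scatter) and a 1.5-fold lower number from compound 1 to compound 4 (0.18 log units; within the scatter) and so compound 4 cannot be told apart from either of them, even though those two stand apart from each other. The compounds shown offer no explanation for these numbers.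

Going by these compounds, it remains open whether an amine or a carboxylic acid in place of the nitrile on the same cyclobutyl ring would also stay this close to compound 3. On these data alone, it is equally open whether the other configuration at the two ring stereocentres of compound 4 would separate the pair, as configuration does for the two 2-cyanocyclopropyl compounds.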